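Aryl exchange at the carbon double-bonded to nitrogen

The source may report more compounds than this note shows. Statements on the series, on what has been measured and on what is new or still open speak of the compounds shown alone.

Measured in a functional assay on COS-7 cells (Chlorocebus aethiops) for inhibition, read by MTT assay; on this read-out higher numbers stand for weaker inhibition and lower numbers for stronger inhibition:
- compound 1 `COc1ccc(/C=N/NC(=S)N/N=C2\C(=O)Nc3ccc(C)cc32)cc1O`: 3190 nM
- compound 2 `COc1ccc(/C=N/NC(=S)N/N=C2\C(=O)Nc3ccc(Br)cc32)cc1O`: 3090 nM

Compound 1 stands highest of the two numbers, with compound 2 nearest at a 1.0-fold lower number from compound 1 to compound 2 (0.01 log units; within the scatter), within the scatter. Compound 3 `Cc1ccc2c(c1)/C(=N/NC(=S)N/N=C/c1c(Cl)cccc1Cl)C(=O)N2` differs from compound 1 by 2,6-dichlorophenyl in place of 3-hydroxy-4-methoxyphenyl on a carbon with a double bond to nitrogen. Within the data shown here, the single measured step, a 1.0-fold lower number from compound 1 to compound 2 (0.01 log units; within the scatter), alters the core and not the aryl at that carbon, so no measured step bears on this change. With nothing to anchor a direction, the expected step in this assay is a 1.0-fold higher number from compound 1 to compound 3 (0.00 log units; within the scatter), none beyond the scatter, carrying a wide uncertainty. Compound 3 is therefore estimated at 3200 nM, range 900 nM to 11000 nM.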

Compound 3, half-maximal inhibitory concentration: 3870 nM
Compound 3: middle estimate off by 1.2-fold (0.08 log units), on the low side; measured number inside the range.
By their numbers in this assay, from the lowest: compounds 2, 1 and 3 (each within the scatter of the next).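

In this assay, the exchange of 3-hydroxy-4-methoxyphenyl for 2,6-dichlorophenyl on a carbon with a double bond to nitrogen gives a 1.2-fold higher number from compound 1 to compound 3 (0.08 log units; within the scatter). Among these compounds, this is the first reading at this position, and the hydrogen-bond donor and acceptors of the leaving aryl go without a step beyond the scatter. No evidence is available on what lies behind this result. Still open, on these data alone, is whether an aryl carrying an amine or a carboxylic acid, or a longer alkyl chain in place of the aryl, would shift the number beyond the scatter. As far as these compounds go, the same exchange on the bromo compound 2 also remains open.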